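The source may report more compounds than this note shows. Statements on the series, on what has been measured and on what is new or still open speak of the compounds shown alone.

In a functional assay on A549 cells (Homo sapiens) for antiproliferative activity, read by MTT assay, with a stated time of 48 h (a higher number here means a weaker inhibitor, a lower number a stronger inhibitor), compound 2 `COc1ccc2c(/C=C/C(=O)c3cc(N)c(OC)c(OC)c3)cn(C)c2c1` gives 106 nM and compound 1 `COc1ccc2c(/C=C/C(=O)c3cc(OC)c(OC)c(SC)c3)c[nH]c2c1` gives 115 nM so the two lie within the usual scatter of each other and neither can be ranked ahead. Compound 3 `COc1ccc2c(/C=C/C(=O)c3cc(OC)c(OC)c(SC)c3)cn(C)c2c1` keeps the core of compound 2 and swaps one group, with methylsulfanyl in place of amino on an aromatic carbon as the counted change: methylsulfanyl in place of amino on an aromatic carbon. For the measured compounds named here, no pair of measured compounds isolates this swap, so the data give no direct guide to its size. Going by the values given here, the only clue is that compound 1 also carries methylsulfanyl and gives 115 nM as its number. The expected outcome is a 1.4-fold lower number from compound 2 to compound 3 (0.15 log units; within the scatter) which would be no shift beyond the scatter, with a slight lean towards a lower number. In this assay the estimated value for compound 3 is 75 nM with an expected range from 20 nM to 280 nM as the likely span.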

Compound 3, half-maximal inhibitory concentration: 156 nM
Estimate against measurement, compound 3: 2.1-fold (0.32 log units) below, within the range that was stated.
By their numbers in this assay, from the lowest: compounds 2, 1 and 3 (each within the scatter of the next).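

In this assay the change of amino to methylsulfanyl now has a measured size: a 1.5-fold higher number from compound 2 to compound 3 (0.17 log units; within the scatter) stays within the scatter, so at this position, ortho to a methoxy group, these two groups cannot be told apart on the shared core, even though amino counts a hydrogen-bond donor and methylsulfanyl counts none. The second pair adds that methyl in place of hydrogen on the aromatic nitrogen also gives no shift beyond the scatter, with a 1.4-fold higher number from compound 1 to compound 3 (0.13 log units; within the scatter) as its step. Nothing measured here explains why either step is so small.

Still open, as far as these compounds go, is whether a hydroxyl, a carboxylic acid or a longer chain such as ethylsulfanyl at this position would move the number beyond the scatter. From the compounds shown here alone, it is also open whether amino would match methylsulfanyl with hydrogen rather than methyl on the aromatic nitrogen.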